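Adding a Hydroxy Group to the Amide Diene Chain

The compounds below may be only part of what the source reports. "The series", "measured", "known", "first", "only" and "open" are said of these compounds alone.

Compound 2, `CCNC(=O)/C=C(C)/C=C/CC(C)CCCC(C)C`, has been measured in a physicochemical assay for lipophilicity (a lower number here means a more polar compound, a higher number a more lipophilic compound), where compound 2 gives 5.24. Among the measured compounds shown here, that is the higher of the two numbers known so far. The other measured compound is compound 1, `CCOC(=O)/C=C(C)/C=C/CC(C)CCCC(C)(C)O`, which in this assay gives 4.65, a number lower than that of compound 2 by more than the scatter of such measurements. Compounds 1 and 2 differ in more than one place, so no single step can be read from their two values.

Compound 3, `CCNC(=O)/C=C(C)/C=C/CC(C)CCCC(C)(C)O`, has not yet been measured. It differs from compound 2 in one place: hydroxy in place of hydrogen on a saturated chain carbon bound to three saturated chain carbons. For the measured compounds named here, no measured pair in this set shows this change alone, so the size of the step is not known from the data. The analyst expects the step in this assay to be downward and beyond the scatter, an estimated a number 1.24 log units lower from compound 2 to compound 3 (beyond the scatter). For compound 3 in this assay the analyst therefore estimates 4, with a range from 3.4 to 4.6.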

Compound 3, partition coefficient: 3.15
Estimate against measurement, compound 3: 0.85 log units above; the measured number lies below the stated range.
By their numbers in this assay, from the lowest: compound 3; then compound 1; then compound 2.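

Among the compounds shown here, with compound 3, the change to hydroxy in place of hydrogen on a saturated chain carbon bound to three saturated chain carbons can be read alone for the first time: in this assay it gives a number 2.09 log units lower from compound 2 to compound 3 (beyond the scatter) and so marks this position as one where the number responds strongly to the change. Compound 3 also makes a second single change readable, as ethylamino in place of ethoxy on a carbonyl carbon, with the hydroxy kept, gives a number 1.50 log units lower from compound 1 to compound 3 (beyond the scatter) and leaves compound 3 with the lowest of the three numbers. Each of these two steps is seen only once, and nothing measured here offers an explanation for either of them.

Going by these compounds, it remains open whether the hydroxy step would have the same size on the ethyl ester, and whether a methoxy group or an amine on the same carbon would give a step like that of the hydroxy. Also open, on these data alone, is how a longer chain carrying the same hydroxy would read in this assay and whether the ethylamino step would hold for a methylamino group on the carbonyl carbon.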